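From Cyclohexyl to 1-Methoxypropyl on a Shared Core

The source may report more compounds than this note shows. Statements on the series, on what has been measured and on what is new or still open speak of the compounds shown alone.

Measured so far in a functional assay on L1210 cells (Mus musculus), with a stated time of 12 days; on this read-out lower numbers stand for lower potency and higher numbers for higher potency (the scale is a negative logarithm):
- compound 1, `CC1=C(N2CC2)C(=O)C(Cc2ccccc2)=C(N2CC2)C1=O`, gives 4.69
- compound 2, `CC1=C(N2CC2)C(=O)C(C2CCCCC2)=C(N2CC2)C1=O`, gives 5.39
- compound 3, `COCCOC(COC(N)=O)C1=C(N2CC2)C(=O)C(C)=C(N2CC2)C1=O`, gives 5.39

Compound 2 stands level with compound 3 at the digits shown, and together they hold the highest numbers of the three; compound 1 lies furthest away, and the only single-point step available, a number 0.70 log units higher from compound 1 to compound 2 (beyond the scatter), is a modest rise that clears the scatter.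

The new compound, compound 4, `CCC(OC)C1=C(N2CC2)C(=O)C(C)=C(N2CC2)C1=O`, is reached from compound 2 by one change: 1-methoxypropyl in place of cyclohexyl on a double-bonded ring carbon. For the measured compounds named here, no measured step covers this exact exchange. The step from compound 1 to compound 2 concerned a ring-for-ring swap at the same position, so it bears only loosely here. Compound 3, which carries an oxygen-containing open chain on its core, sits level with compound 2, which gives some reason to expect that an open chain with an acceptor need not cost potency. On that basis the step of a number 0.09 log units lower from compound 2 to compound 4 (within the scatter) is expected to stay within the scatter. Compound 4 is therefore estimated at 5.3, with a range from 4.8 to 5.8.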

Compound 4, logarithm of the reciprocal of the active concentration, log(1/C): 5.33
For compound 4 the middle estimate is 0.03 log units below the measured one, and the stated range covers the measured number.
By their numbers in this assay, from the lowest: compound 1; then compounds 4, 2 and 3 (each within the scatter of the next).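

In this assay, the double-bonded ring carbon accepts an open chain in place of a closed ring, with a number 0.06 log units lower from compound 2 to compound 4 (within the scatter). Cyclohexyl, a six-membered ring of carbon only with no hydrogen-bond acceptor, and 1-methoxypropyl, which has no ring and carries one hydrogen-bond acceptor, therefore read alike at this position, something the earlier single-place step could not show. Benzyl now stands apart from two different groups rather than one, with a number 0.64 log units higher from compound 1 to compound 4 (beyond the scatter), and nothing available accounts for these numbers.

From the compounds shown here alone, the ring leaves and the oxygen enters in the same exchange, so the share of each remains open, and a plain butyl chain on the same carbon would help to separate them. Also open, going by these compounds, is how an amine or a carboxylic acid at the end of such a chain would read in this assay, and whether the match between cyclohexyl and 1-methoxypropyl would hold for longer chains.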